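A few compounds are considered here, and "the series" means these few. Any claim that something is new, unique, unknown or untested is made for them only; others in the source may bear on it.

Of the compounds shown here, three with a shared core have been measured in a functional assay on MCF7 cells (Homo sapiens) for cytotoxicity, read by CellTiter-Glo, with a stated time of 5 days; on this read-out higher numbers stand for weaker inhibition and lower numbers for stronger inhibition. Compound 1, `CC/C(=C(\c1ccc2[nH]ncc2c1)c1ccc(/C=C/C(=O)O)cc1C)c1ccccc1`, gives 36 nM in this assay. Compound 2, `CC/C(=C(/c1csc(/C=C/C(=O)O)c1)c1ccc2[nH]ncc2c1)c1ccccc1`, gives 2900 nM in this assay. Compound 3, `CC/C(=C(/c1ccc(/C=C/C(=O)O)cc1)c1ccc2[nH]ncc2c1)c1cccc(Cl)c1`, gives 12 nM in this assay, the lowest of the three numbers: compound 1 lies closest to it and compound 2 farthest, and both gaps are beyond the usual scatter of repeat measurements, so compound 3 is the strongest inhibitor among the three.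

The next compound, compound 4, `CC/C(=C(/c1ccc(/C=C/C(=O)O)cc1)c1ccc2[nH]ncc2c1)c1cccnc1C`, differs from compound 3 in one place: 2-methylpyridin-3-yl in place of 3-chlorophenyl on a double-bonded chain carbon bound to a double-bonded chain carbon and a saturated chain carbon. Among the measured compounds shown here, no measured pair shows this change directly, so its effect can only be judged from the spread seen so far. A step of modest size is expected a 2.5-fold higher number from compound 3 to compound 4 (0.40 log units; beyond the scatter), toward a somewhat higher number, but it may also turn out to lie within the scatter. Compound 4 is therefore estimated at 30 nM in this assay, with a plausible range from 10 nM to 90 nM.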

Compound 4, half-maximal inhibitory concentration: 200 nM
Compound 4: the middle estimate sits 6.7-fold (0.82 log units) below what was measured; the measured number lies above the stated range.
By their numbers in this assay, from the lowest: compound 3; then compound 1; then compound 4; then compound 2.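

Replacing 3-chlorophenyl with 2-methylpyridin-3-yl gives a 17-fold higher number from compound 3 to compound 4 (1.22 log units; beyond the scatter) in this assay, so this place on the shared core is sensitive to the identity of the group it carries. Both groups have a six-membered aromatic ring and the same count of heavy atoms, so those two counts alone do not fix the number here. The change swaps several features at once, losing the chlorine while adding a ring nitrogen and a methyl, and no supporting measurement accounts for the step.

The compounds shown leave open which of those features carries the step. A 2-methylphenyl or a pyridin-3-yl group at this place on the core of compound 3 would begin to separate the methyl from the ring nitrogen.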